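The source may report more compounds than this note shows. Statements on the series, on what has been measured and on what is new or still open speak of the compounds shown alone.

Measured so far in a functional assay on MCF7 cells (Homo sapiens) for cytotoxicity, read by MTT assay, with a stated time of 48 h; a higher number here means a weaker inhibitor, a lower number a stronger inhibitor:
compound 1 `CCN(CC)C(=S)SC(CC(=O)c1ccccc1)c1ccc(C)cc1` gives 20000 nM
compound 2 `CCN(CC)C(=S)SC(CC(=O)c1ccccc1)c1ccc(Cl)cc1` gives 120 nM

Compound 1 stands highest of the two numbers; its nearest neighbour is compound 2, reached by a 170-fold lower number from compound 1 to compound 2 (2.22 log units; beyond the scatter). The step under consideration runs from compound 1 to compound 3 `CCN(CC)C(=S)SC(CC(=O)c1ccccc1)c1cccc([N+](=O)[O-])c1`: 3-nitrophenyl in place of 4-methylphenyl on a saturated chain carbon bound to a saturated chain carbon and a sulfur. Among the compounds with values here, only one measured step bears on it, the exchange at the same place that gave a 170-fold lower number from compound 1 to compound 2 (2.22 log units; beyond the scatter), a large move to a lower number. The change to compound 3 removes the same 4-methylphenyl but brings in a 3-nitrophenyl, a group absent from both measured compounds, so the size of the effect cannot be read directly from the data. Since the one replacement of the 4-methylphenyl measured so far moved the number far down, a lower number than compound 1 is expected for compound 3 as well, though with wide uncertainty. The expected step is a 13-fold lower number from compound 1 to compound 3 (1.12 log units; beyond the scatter). Compound 3 is estimated at 1500 nM, within 200 nM to 15000 nM.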

Compound 3, half-maximal inhibitory concentration: 9000 nM
Beside the measured number, compound 3's estimate is 6.0-fold (0.78 log units) below it; low and high end bracket the measured number.
By their numbers in this assay, from the lowest: compound 2; then compound 3; then compound 1.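

In this assay, losing the 4-methylphenyl is not enough by itself to produce a large fall in the number: the 3-nitrophenyl gives only a 2.2-fold lower number from compound 1 to compound 3 (0.35 log units; beyond the scatter), a modest step. The same position still separates the aryl groups sharply, with a 75-fold higher number from compound 2 to compound 3 (1.88 log units; beyond the scatter), so the low number of compound 2 goes with the 4-chlorophenyl specifically, not with any replacement of the 4-methylphenyl. No measurement at hand accounts for this difference between the groups.

The 3-nitrophenyl differs from the 4-chlorophenyl in both its substituent and the numbered ring place of that substituent, and these three compounds cannot separate the two changes. Also open, from the compounds shown here alone, is where an unsubstituted phenyl, or a ring carrying fluoro or methoxy, would fall at this position.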